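From dimethylsulfamoyl to diethylsulfamoyl: working notes

The source may hold more compounds than are shown below. What is called first, only, known or untested is meant among the compounds shown, and "the series" means these compounds.

In a functional assay on the whole organism (strain Sprague-Dawley) for inhibition, with Rattus norvegicus as the target, with a stated time of 10 min (a higher number here means that more compound is needed for the effect, a lower number that less compound is needed), compound 1 `CCOc1ccc([N+](=O)[O-])cc1-c1ncc(C(=O)O)c(=O)[nH]1` gives 25 mg/kg. In this assay compound 2 `CCOC(=O)C(=O)Nc1ccc(OCC)c(-c2ncc(C(=O)O)c(=O)[nH]2)c1` gives 25 mg/kg. Compound 3 `CCOc1ccc(S(=O)(=O)N(C)C)cc1-c1ncc(C(=O)O)c(=O)[nH]1` gives > 50 mg/kg, which is a limit of the assay and not a number. It is the only one of the three without a numeric value.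

Compound 4 `CCOc1ccc(S(=O)(=O)N(CC)CC)cc1-c1ncc(C(=O)O)c(=O)[nH]1` carries diethylamino in place of dimethylamino on a sulfonyl sulfur. In words, diethylamino stands in place of dimethylamino on a sulfonyl sulfur, so dimethylsulfamoyl becomes diethylsulfamoyl.

Within the data shown here, no measured step changes the amine on the sulfonyl sulfur, so the available steps bear on this change only indirectly. Dimethylsulfamoyl in place of nitro gave an at least 2.0-fold higher number from compound 1 to compound 3 (0.30 log units; that floor lies within the scatter). Dimethylsulfamoyl in place of ((ethoxycarbonyl)carbonyl)amino gave an at least 2.0-fold higher number from compound 2 to compound 3 (0.30 log units; that floor lies within the scatter). ((Ethoxycarbonyl)carbonyl)amino in place of nitro gave no change at the digits printed from compound 1 to compound 2 (within the scatter). All three exchange a whole group at one place, and none of them shows a step beyond the scatter.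

No shift beyond the scatter, in either direction, is therefore expected in this assay. The expected step is a step that the limit leaves unreadable from compound 3 to compound 4. The expectation starts from compound 3, whose > 50 mg/kg is again a limit, so compound 4 may also be reported only as a limit. The estimate for compound 4 is 60 mg/kg, with an expected range of 25 mg/kg to 120 mg/kg.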

Compound 4, dose for 50% inhibition: 40 mg/kg
Estimate against measurement, compound 4: 1.5-fold (0.18 log units) above, and the stated range covers the measured number.
By their numbers in this assay, from the lowest: compounds 1, 2 and 4 (each within the scatter of the next). At a limit, above all of these: compound 3.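

In this assay, among these compounds, compound 4 gives 40 mg/kg as the first numeric value for a sulfamoyl group at this place, where the only earlier sulfamoyl compound offered no number. Compound 3 remains a limit of the assay and not a number: the limit of > 50 mg/kg in this assay, at which 1 of the 4 values shown sits. Diethylamino in place of dimethylamino on a sulfonyl sulfur gives an at least 1.2-fold lower number from compound 3 to compound 4 (0.09 log units; that floor lies within the scatter) while diethylsulfamoyl gives a 1.6-fold higher number from compound 2 to compound 4 (0.20 log units; within the scatter) and a 1.6-fold higher number from compound 1 to compound 4 (0.20 log units; within the scatter) so diethylsulfamoyl, nitro and ((ethoxycarbonyl)carbonyl)amino on this aromatic carbon are not told apart by these numbers.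

Still open, on these data alone, is whether any change at this place moves the number in this assay beyond the scatter, and how far the dimethylamino to diethylamino step really runs, given that its size rests on a floor. A longer chain on the sulfonyl sulfur, such as dipropylamino, or a free amine in place of the nitro group, would bear directly on both questions.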